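Cyclobutyl for Ethyl on the Carbonyl Carbon

The compounds below may be only part of what the source reports. "The series", "measured", "known", "first", "only" and "open" are said of these compounds alone.

Of the compounds shown here, three have been measured in an assay on isolated protein for inhibition of Nitric oxide synthase, inducible (Homo sapiens), with a stated time of 30 min, tested at 1 mM; a higher number here means more inhibition at the concentration tested (going by the name of the read-out), a lower number less inhibition. Compound 1, `Nc1ccc(Cl)cc1C1=NN(C(=O)C2CC2)CC1`, gives 18.9% in this assay. Compound 2, `Nc1ccc(Cl)cc1C1=NN(C(=O)c2ccccc2)CC1`, gives 17%. Among the measured compounds shown here, the step of a number 1.9 percentage points lower from compound 1 to compound 2 (within the scatter) is the only change at the carbonyl carbon measured so far. Compound 3, `CCC(=O)N1CCC(c2cc(OC)ccc2N)=N1`, gives 20.4% in this assay; its number lies within the scatter of both compound 1 and compound 2, so no ranking of the three is justified.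

Compound 4, `COc1ccc(N)c(C2=NN(C(=O)C3CCC3)CC2)c1`, differs from compound 3 by cyclobutyl in place of ethyl on a carbonyl carbon. For the measured compounds named here, the one measured step at this place stayed within the scatter, so little movement is expected here either. The step of a number 0.4 percentage points lower from compound 3 to compound 4 (within the scatter) is expected to remain within the scatter. Compound 4 is therefore estimated at 20% in this assay, with a range from 12% to 28%.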

Compound 4, a percentage reported as inhibition, at one concentration (the size of the read-out at that concentration, not a potency): 1.91%
Beside the measured number, compound 4's estimate is 18.1 percentage points above it, outside the stated range (below it).
By their numbers in this assay, from the lowest: compound 4; then compounds 2, 1 and 3 (each within the scatter of the next).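

In this assay, cyclobutyl in place of ethyl on a carbonyl carbon gives a number 18.5 percentage points lower from compound 3 to compound 4 (beyond the scatter), so a change at this place can move the read-out well beyond the scatter. This single pair cannot show whether the ring or the larger group count goes with the lower number. Nothing available explains the drop.

Open, from the compounds shown here alone, is whether a longer open chain, such as butyl, on the same carbonyl carbon of the core of compound 3 would stay near compound 3 or fall towards compound 4.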